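The compounds below may be only part of what the source reports. "The series", "measured", "known", "first", "only" and "open" are said of these compounds alone.

Working notes on the series. Compound 1 `Cc1c(C(=O)Nc2ccc(Oc3ncnc4[nH]cc(-c5ccccc5)c34)c(F)c2)c(=O)c2cc(F)ccc2n1C` is the starting point. In an assay on isolated protein for inhibition of tyrosine-protein kinase receptor UFO (Homo sapiens), read by FRET and Z'-LYTE, with a stated time of 1.5 h (on this read-out higher numbers stand for weaker inhibition and lower numbers for stronger inhibition), compound 1 gives > 10000 nM, which is a limit of the assay and not a number. Compound 1 therefore stands at the weak end of what has been measured here, together with compound 3 `CCc1ccc2c(c1)c(=O)c(C(=O)Nc1ccc(Oc3ccnc(C(N)=O)c3Cl)c(F)c1)c(C)n2C`, which in this assay also gives > 10000 nM, again a limit and not a number; both sit at the limit of > 10000 nM in this assay, at which 2 of the 3 values shown sit. Compound 2 `CCc1ccc2c(c1)c(=O)c(C(=O)Nc1ccc(Oc3cccc4occ(-c5ccccc5)c34)c(F)c1)c(C)n2C`, which carries a different aryl ether partner and an ethyl on the quinolone ring, gives 192 nM in this assay.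

Compound 4 `CCCc1ccc2c(c1)c(=O)c(C(=O)Nc1ccc(Oc3ncnc4[nH]cc(-c5ccccc5)c34)c(F)c1)c(C)n2C` keeps the aryl ether of compound 1 and differs from it only on the quinolone ring: propyl in place of fluoro on an aromatic carbon. Among the measured compounds shown here, no measured pair shows this change on its own. Compound 2 shows that an alkyl chain at this position can be carried by a compound with a measurable value in this assay, but its aryl ether is not that of compound 1, so the change cannot be separated from the ether. The step from compound 1 to compound 4 is expected to be an at least 3.3-fold lower number from compound 1 to compound 4 (0.52 log units; beyond the scatter), in the direction of stronger inhibition but with little confidence. Compound 4 is estimated at 3000 nM, in the range 300 nM to 15000 nM.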

Compound 4, half-maximal inhibitory concentration: 61 nM
For compound 4 the middle estimate is 49-fold (1.69 log units) above the measured one; the whole stated range lies above it.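

With the aryl ether of compound 1 held fixed, propyl in place of fluoro on an aromatic carbon gives an at least 160-fold lower number from compound 1 to compound 4 (2.21 log units; beyond the scatter) in this assay, so a change at this position alone is enough to bring the compound from the limit to a measured value. Compound 2 could not show this, as it carries a different aryl ether, whereas here the ether stays the same and only the group at this position differs. Going by these compounds, compound 1 gives > 10000 nM, which is a limit and not a number, and the true size of the step stays unknown because the step starts from that limit: the limit of > 10000 nM in this assay, at which 2 of the 4 values shown sit.

Among the compounds shown here, whether the effect follows from chain length, or from an alkyl group as such, remains open, since fluoro and propyl are the only groups compared on this ether, and a butyl chain, a methoxy group or an amine at this position could help to separate these readings. Whether propyl would give a similar step with the aryl ether of compound 2 also remains open, as no matched pair on that ether is shown.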